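The source may report more compounds than this note shows. Statements on the series, on what has been measured and on what is new or still open speak of the compounds shown alone.

Measured compounds:
compound 1 `COc1ccc(/C=C/C(=O)c2cccc(I)c2)cc1` — > 100000 nM
compound 2 `O=C(/C=C/c1ccco1)c1ccc(N2CCCCC2)cc1` — "not determined" (no result reported)
compound 3 `Cc1ccc(C(=O)/C=C/c2ccc([N+](=O)[O-])s2)cc1` — "not determined" (no result reported)

In an ADME assay on Vero cells (Chlorocebus sabaeus) for cytotoxicity, read by resazurin assay, with a stated time of 72 h (on this read-out higher numbers stand for lower toxicity in this test and lower numbers for higher toxicity in this test), compound 1 gives > 100000 nM, which is a limit of the assay rather than a number. Compound 2 has no result in this assay, and the same holds for compound 3. Among the three entries, compound 1 is the only one with any reading at all, and that reading sits at the limit of > 100000 nM in this assay, at which 1 of the 3 values shown sits.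

Compound 4 `COc1ccc(/C=C/C(=O)c2cccc(Br)c2)cc1` is not yet measured. It differs from compound 1 by bromo in place of iodo on an aromatic carbon. Among the compounds with values here, no measured step between two compounds is available to guide the size of this change. Given that compound 1 sits at a limit > 100000 nM, compound 4 is expected to show no step beyond the scatter, a step that the limit leaves unreadable from compound 1 to compound 4. Compound 4 is estimated at 150000 nM, within 50000 nM to 500000 nM, most likely again reported only as a limit.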

Compound 4, half-maximal cytotoxic concentration: > 100000 nM
Compound 4 was reported as a limit; the forecaster's own chance of this, stated with the estimate: 80%; the middle value does not contradict the limit.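

In this assay, within the data shown here, compound 1 and compound 4 are both reported only as limits, and no step between them can be read. The compounds shown leave open what bromo in place of iodo on an aromatic carbon does to this read-out.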